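Swapping Methoxy for Isopropoxy on the Benzyl Ether

This account rests on a few compounds, and the source may have more. Where it says the series, first, only, none or still open, it means among the compounds named here.

Of the compounds shown here, three built on one shared core have been tested in a functional assay on PC-3 cells (Homo sapiens) for cytotoxicity, read by sulforhodamine B assay; on this read-out higher numbers stand for weaker inhibition of growth and lower numbers for stronger inhibition of growth. Compound 1 `COc1cccc(OC)c1OCCNCCOc1ccccc1OCc1cccc([N+](=O)[O-])c1` gives 38900 nM. Compound 2 `COc1cccc(OC)c1OCCNCCOc1ccccc1OCc1ccc([N+](=O)[O-])cc1` gives 43600 nM. Compound 3 `COc1ccc(COc2ccccc2OCCNCCOc2c(OC)cccc2OC)cc1` gives 34700 nM, the lowest of the three numbers, although its separation from the others is slight: a 1.1-fold lower number from compound 1 to compound 3 (0.05 log units; within the scatter) and a 1.3-fold lower number from compound 2 to compound 3 (0.10 log units; within the scatter), both within the scatter, as is a 1.1-fold higher number from compound 1 to compound 2 (0.05 log units; within the scatter). Compound 4 `COc1cccc(OC)c1OCCNCCOc1ccccc1OCc1ccc(OC(C)C)cc1` differs from compound 3 in a single place: isopropyl in place of methyl on an oxygen on an aromatic ring. Within the data shown here, none of the measured steps touches this oxygen; they exchange the aryl group on the benzyl carbon or replace its nitro group with methoxy, and not one of them carried the number beyond the scatter. Among the measured compounds shown here, the only guide is therefore the flatness of the whole set. On that basis the step from compound 3 to compound 4 is expected to be a 1.1-fold lower number from compound 3 to compound 4 (0.04 log units; within the scatter), with no clear direction. Compound 4 is estimated to give 32000 nM in this assay, within a range of 15000 nM to 65000 nM.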

Compound 4, concentration for total growth inhibition: 17800 nM
Beside the measured number, compound 4's estimate is 1.8-fold (0.25 log units) above it; the range from low to high includes it.
By their numbers in this assay, from the lowest: compounds 4, 3, 1 and 2 (each within the scatter of the next, the first and the last beyond it).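

In this assay, among these compounds, the 4-isopropoxyphenyl group yields the only steps in the set that pass the scatter, with a 2.4-fold lower number from compound 2 to compound 4 (0.39 log units; beyond the scatter) and a 2.2-fold lower number from compound 1 to compound 4 (0.34 log units; beyond the scatter) both modest, whereas every step among the earlier compounds stayed inside it. The direct change on this oxygen, isopropyl in place of methyl, gives a 1.9-fold lower number from compound 3 to compound 4 (0.29 log units; within the scatter) and so stays within the scatter, which means this pair alone does not separate the methoxy and isopropoxy groups. No measurement at hand bears on the cause of these steps.

The compounds shown leave open whether a longer chain on this oxygen, such as butyl, or a cyclopentyl ring would move the number further from that of compound 3. They also leave open how an amine or a carboxylic acid at this place on the ring would read.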